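Methoxy on the terminal phenyl across two cores

The source may hold more compounds than are shown below. What is called first, only, known or untested is meant among the compounds shown, and "the series" means these compounds.

Measured compounds:
- compound 1, `O=C(NNc1nc2ccccc2nc1Cc1ccccc1)c1ccccc1`: 78 nM
- compound 2, `COc1ccc(C(=O)NNc2nc3ccccc3nc2Cc2ccccc2)cc1`: 86 nM
- compound 3, `O=C(Cn1c(=O)c(Cc2ccccc2)nc2ccccc21)N/N=C/c1ccccc1`: 3.1 nM

All values come from an assay for inhibition of Amine oxidase [flavin-containing] A (Bos taurus), read by fluorescence, with a stated time of 60 min; a higher number here means a weaker inhibitor, a lower number a stronger inhibitor. Compound 1 and compound 2 share one core and differ only by methoxy in place of hydrogen on an aromatic carbon; the step of a 1.1-fold higher number from compound 1 to compound 2 (0.04 log units; within the scatter) is within the scatter, so the two values show no order. Compound 3 has a different core; the difference between the two cores is not broken down here. In this assay compound 3 gives the lowest of the three numbers, with the nearest measured compound sitting far above it.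

Compound 4, `COc1ccc(/C=N/NC(=O)Cn2c(=O)c(Cc3ccccc3)nc3ccccc32)cc1`, is not yet measured. For the measured compounds named here, it differs from compound 3 by methoxy in place of hydrogen on an aromatic carbon, the same change as the one between compound 1 and compound 2, made on the core of compound 3. Because a 1.1-fold higher number from compound 1 to compound 2 (0.04 log units; within the scatter) was within the scatter, the expected step is a 1.1-fold higher number from compound 3 to compound 4 (0.05 log units; within the scatter), of similar size. On that basis compound 4 is expected to give about 3.5 nM in this assay, most likely between 1.5 nM and 8 nM.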

Compound 4, half-maximal inhibitory concentration: 6.6 nM
Compound 4: middle estimate off by 1.9-fold (0.28 log units), on the low side; measured number inside the range.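

On the core of compound 3, the change from phenyl to 4-methoxyphenyl gives a 2.1-fold higher number from compound 3 to compound 4 (0.33 log units; beyond the scatter), a modest step, while on the core of compound 1 the same change gives a 1.1-fold higher number from compound 1 to compound 2 (0.04 log units; within the scatter). For the compounds shown here, the two steps cannot be told apart, so the data fit a change that carries over between these cores with a similar small effect, even though only the step on the core of compound 3 lies beyond the scatter on its own: the same change on two cores in this assay, a 1.1-fold higher number (0.04 log units; within the scatter) from compound 1 to compound 2 and a 2.1-fold higher number (0.33 log units; beyond the scatter) from compound 3 to compound 4, 1.9-fold (0.29 log units) apart, within the scatter of two such steps. With a single pair on each core, this neither establishes a general transfer rule for the series nor shows that the core has any influence on the step, and it gives no reason for the step's size.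

From the compounds shown here alone, whether a hydroxyl, a chlorine or an amine on the same aromatic carbon would give similar steps on both cores remains open. Also open, going by these compounds, is whether a carboxylic acid or a longer alkoxy chain there would carry over in the same way.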